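Hexyl for cyclopropyl at the propargylic ether carbon

The source may hold more compounds than are shown below. What is called first, only, known or untested is meant among the compounds shown, and "the series" means these compounds.

Going by the values given here, compound 1 `COC(=O)C#CC(O/C=C/C(=O)OC)C1CC1` is the only member with a measured number in a functional assay on HBL-100 cells (Homo sapiens) for antiproliferative activity, read by sulforhodamine B assay, with a stated time of 48 h; a higher number here means a weaker inhibitor of growth, a lower number a stronger inhibitor of growth; compound 1 gives 250 nM. Compound 2 `C#CCO/C=C/C(=O)OC` returns only a limit of the assay, > 100000 nM. Compound 3 `CC1CCC(C(C)C)C(OC(=O)C#CC(O/C=C/C(=O)OC2CC(C)CCC2C(C)C)C(C)C)C1` likewise returns only a limit, > 100000 nM. Among the compounds with values here, two of the three values thus sit at the limit of > 100000 nM in this assay, at which 2 of the 3 values shown sit, so no measured step between compounds can be drawn and compound 1 stands alone with a number. Compound 4 `CCCCCCC(C#CC(=O)OC)O/C=C/C(=O)OC` differs from compound 1 by hexyl in place of cyclopropyl on a saturated chain carbon bound to an oxygen on an unsaturated carbon and a triple-bonded carbon. With nothing measured to lean on, the change is expected to shift the value in this assay by no more than the usual scatter, in no fixed direction. Compound 4 is therefore estimated at 300 nM, with a range from 60 nM to 1500 nM. That estimate corresponds to an expected step of a 1.2-fold higher number from compound 1 to compound 4 (0.08 log units; within the scatter).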

Compound 4, concentration for 50% growth inhibition: 2500 nM
Compound 4: middle estimate off by 8.3-fold (0.92 log units), on the low side, and the stated range ends below it.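

In this assay, going by these compounds alone, hexyl in place of cyclopropyl gives a 10-fold higher number from compound 1 to compound 4 (1.00 log units; beyond the scatter) on this saturated chain carbon, the first measured step, so the position is not indifferent to the group it carries. Compound 4 still returns a number and not a limit, so growth inhibition remains measurable with this open chain at the position.

Whether the step follows from the chain length or from the loss of the ring stays open, as neither a propyl chain nor a cyclohexyl ring stands at this position among the compounds shown. Nothing shown accounts for the step.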